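This account rests on a few compounds, and the source may have more. Where it says the series, first, only, none or still open, it means among the compounds named here.

The measured compounds:
compound 1, `O=C(CSc1nc(Nc2ccccc2)c2ccccc2n1)Nc1cccc([N+](=O)[O-])c1`; in a functional assay on NCI-H1975 cells (Homo sapiens) for inhibition, read by MTT assay, with a stated time of 72 h (on this read-out lower numbers stand for stronger inhibition and higher numbers for weaker inhibition), compound 1 gives 17900 nM.
compound 2, `CCc1cccc(NC(=O)CSc2nc(Nc3ccccc3)c3ccccc3n2)c1`; compound 2 gives 12000 nM.
compound 3, `COc1cccc(NC(=O)CSc2nc(Nc3ccccc3)c3ccccc3n2)c1`; compound 3 gives 19400 nM.

All three share one core and differ only in the group carried on the amide-type nitrogen. Compound 2 stands within the scatter of both companions: a 1.5-fold lower number from compound 1 to compound 2 (0.17 log units; within the scatter), and a 1.6-fold higher number from compound 2 to compound 3 (0.21 log units; within the scatter). The third step, a 1.1-fold higher number from compound 1 to compound 3 (0.03 log units; within the scatter), is also within the scatter, so the three numbers cannot be told apart.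

Compound 4, `O=C(CSc1nc(Nc2ccccc2)c2ccccc2n1)Nc1ccc(Cl)c(Cl)c1`, has not yet been measured in this assay. It differs from compound 2 in one place: 3,4-dichlorophenyl in place of 3-ethylphenyl on an amide-type nitrogen. The three measured steps all bear on it, since each is an exchange of one group at the same place, and none of them moved the number beyond the scatter. A further exchange at that place is therefore expected to give no step beyond the scatter either: a 1.1-fold higher number from compound 2 to compound 4 (0.03 log units; within the scatter). Compound 4 is estimated to give about 13000 nM, with a range from 5000 nM to 35000 nM.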

Compound 4, half-maximal inhibitory concentration: 10400 nM
The estimate for compound 4 lay 1.3-fold (0.10 log units) above the measured number; low and high end bracket the measured number.
By their numbers in this assay, from the lowest: compounds 4, 2, 1 and 3 (each within the scatter of the next).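

In this assay, 3,4-dichlorophenyl on the amide-type nitrogen gives a 1.2-fold lower number from compound 2 to compound 4 (0.06 log units; within the scatter) and a 1.9-fold lower number from compound 3 to compound 4 (0.27 log units; within the scatter) and also a 1.7-fold lower number from compound 1 to compound 4 (0.24 log units; within the scatter) and so cannot be told apart from 3-ethylphenyl, 3-methoxyphenyl or 3-nitrophenyl. The earlier compounds shown here each carried one group on this phenyl ring, whereas compound 4 carries two chlorine atoms, and this place still shows no step beyond the scatter. No measurement shown here explains why these four numbers stay together.

Still open, going by these compounds, is what an amine or a carboxylic acid on this ring would do, or a plain alkyl chain in place of the ring, and whether any exchange here gives a step beyond the scatter. On these data alone, all four compounds keep the shared core unchanged, so the effect of changes elsewhere in it also stays open.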